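The compounds below may be only part of what the source reports. "The series", "measured", "known", "first", "only" and "open" are said of these compounds alone.

Compound 2 `Nc1ncc(-c2cc([C@@H]3CCCO3)nc(N3C[C@@H]4C[C@H]3CO4)n2)nc1OC(F)F` and compound 1 `CCOC(=O)N1C[C@@H]2C[C@H]1CN2c1nc(SC)cc(-c2cnc(N)c(OC(F)F)n2)n1` have both been tested in an assay on Sf21 cells for inhibition of mitogen-activated protein kinase kinase kinase 13 (Homo sapiens), read by HTRF, with a stated time of 1.5 h; on this read-out higher numbers stand for weaker inhibition and lower numbers for stronger inhibition. Compound 2 gives 23 nM, and compound 1 gives 44 nM; the two numbers lie within the scatter of one another, so neither stands apart. Compound 3 `Nc1ncc(-c2cc(C3CC3)nc(N3C[C@@H]4C[C@H]3CO4)n2)nc1OC(F)F` differs from compound 2 in a single change: cyclopropyl in place of oxolan-2-yl on an aromatic carbon. For the measured compounds named here, no measured pair shows this change. In this assay a small shift toward weaker inhibition is expected, though not clearly beyond the scatter, and the step is expected to be a 1.7-fold higher number from compound 2 to compound 3 (0.24 log units; within the scatter). Compound 3 is therefore estimated at 40 nM, with a range from 12 nM to 130 nM.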

Compound 3, half-maximal inhibitory concentration: 61 nM
Estimate against measurement, compound 3: 1.5-fold (0.18 log units) below; the range from low to high includes it.
By their numbers in this assay, from the lowest: compounds 2, 1 and 3 (each within the scatter of the next, the first and the last beyond it).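

In this assay, for the compounds shown here, the swap of oxolan-2-yl for cyclopropyl on this aromatic carbon gives a 2.7-fold higher number from compound 2 to compound 3 (0.42 log units; beyond the scatter) and so shows, as the earlier compounds could not, that the group held here affects the reading, if modestly. The swap removes the ring oxygen and the defined stereocentre together, so the step cannot be assigned to either alone. No measurement shown gives a reason for this step.

The compounds shown leave open how an amine such as pyrrolidin-1-yl or an open chain such as methoxymethyl would read on this carbon. They also leave open how the mirror-image form of oxolan-2-yl would compare with that of compound 2.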